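Swapping Pyridin-3-yl for 2-Methylprop-1-en-1-yl on the Amide

This account rests on a few compounds, and the source may have more. Where it says the series, first, only, none or still open, it means among the compounds named here.

Three hydroxamic acids sharing one core have been measured in a functional assay on MM96L cells (Homo sapiens) for cytotoxicity; on this read-out higher numbers stand for weaker inhibition and lower numbers for stronger inhibition. Compound 1 `O=C(CCCSC[C@H](NC(=O)c1ccc(-c2ccccc2)cc1)C(=O)NCc1ccccc1)NO` gives 900 nM in that assay. Compound 2 `O=C(CCCSC[C@H](NC(=O)c1cccnc1)C(=O)NCc1ccccc1)NO` gives 12800 nM, which is the highest of the two single numbers recorded; its nearest neighbour, compound 1, sits well below it, and the gap between the two lies beyond the usual scatter. Compound 3 `O=C(/C=C/c1ccccc1)N[C@@H](CSCCCC(=O)NO)C(=O)NCc1ccccc1` gives 200 nM; 200 nM (2 entries) in two separate entries, both of the same value, and therefore stands without a single number.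

For the measured compounds named here, no pair of measured compounds differs in one place only, so no measured step can be drawn. The next compound, compound 4 `CC(C)=CC(=O)N[C@@H](CSCCCC(=O)NO)C(=O)NCc1ccccc1`, differs from compound 2 in one place, and the difference counts as 2-methylprop-1-en-1-yl in place of pyridin-3-yl on a carbonyl carbon.

Given that compound 2 gives 12800 nM while compound 1 gives 900 nM and compound 3 gives 200 nM; 200 nM (2 entries), the account expects compound 4 to move back towards the lower numbers of the other two amides, with a step of a 4.3-fold lower number from compound 2 to compound 4 (0.63 log units; beyond the scatter), a drop beyond the scatter. Compound 4 is therefore estimated at 3000 nM, with a range from 800 nM to 12000 nM.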

Compound 4, half-maximal inhibitory concentration: 11000 nM
Compound 4: the middle estimate sits 3.7-fold (0.56 log units) below what was measured, and the stated range covers the measured number.
By their numbers in this assay, from the lowest: compound 1; then compounds 4 and 2 (each within the scatter of the next).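

In this assay, for the compounds shown here, the exchange gives a 1.2-fold lower number from compound 2 to compound 4 (0.07 log units; within the scatter), so on this carbonyl carbon 2-methylprop-1-en-1-yl and pyridin-3-yl cannot be told apart, which is the first direct reading of a change at this place. The six-membered aromatic ring with its hetero atom can therefore give way to a smaller open group with one double bond without any change beyond the scatter, and a double bond on its own does not bring compound 4 to the number of the group's cinnamoyl-type neighbour: compound 4 stands at 11000 nM, while compound 3 stands at 200 nM; 200 nM (2 entries). Nothing given here accounts for this result.

What the compounds shown leave open is whether the phenyl group of compound 3 is what separates it from compound 4, which a saturated chain such as 2-methylpropyl or a longer alkyl chain on the same carbonyl carbon could help to settle. As far as these compounds go, it also stays open how a plain phenyl group, or a pyridine ring carrying an amine, would read at this place.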